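Sulfonyl aryl exchange in a benzylamide sulfonamide series

A few compounds are considered here, and "the series" means these few. Any claim that something is new, unique, unknown or untested is made for them only; others in the source may bear on it.

Compound 1 `O=C(NCc1ccc(CNS(=O)(=O)c2ccccc2Cl)cc1)c1cccnc1` is the reference point of the pair measured so far. In an assay on MDA-MB-231 cells for displacement of a labelled ligand from C-X-C chemokine receptor type 4 (Homo sapiens), read by fluorescence and microscopy, with stated times of 10 min and 30 min (a lower number here means that less compound is needed, a higher number that more compound is needed for the effect), compound 1 gives 100 nM, the lowest of the two numbers; its nearest neighbour is compound 2 `Cc1ccccc1C(=O)NCc1ccc(CNS(=O)(=O)c2ccccc2Cl)cc1`, which gives 1000 nM. Within the data shown here, the only measured step, a 10-fold higher number from compound 1 to compound 2 (1.00 log units; beyond the scatter), concerns the group on the carbonyl carbon and is modest.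

Compound 3 `O=C(NCc1ccc(CNS(=O)(=O)c2ccc(F)cc2)cc1)c1cccnc1` is not yet measured. Its change from compound 1 is 4-fluorophenyl in place of 2-chlorophenyl on a sulfonyl sulfur, on the sulfonyl sulfur. Among the measured compounds shown here, no measured step touches that part of the shared core, so the measured step from compound 1 to compound 2 does not bear on it and gives no guide to direction. With nothing measured at the sulfonyl side, the expectation for compound 3 is a value near that of compound 1, widened to allow for either direction, so that a 2.0-fold higher number from compound 1 to compound 3 (0.30 log units; within the scatter) is expected to lie within the scatter or somewhat beyond it. The estimate for compound 3 in this assay is 200 nM, with a range from 50 nM to 1000 nM.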

Compound 3, effective concentration (reported as EC, without a stated level of effect): 100 nM
Beside the measured number, compound 3's estimate is 2.0-fold (0.30 log units) above it; the range from low to high includes it.
By their numbers in this assay, from the lowest: compounds 1 and 3 (each within the scatter of the next); then compound 2.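

Among these compounds, at the sulfonyl sulfur, 4-fluorophenyl in place of 2-chlorophenyl gives no change at the digits printed from compound 1 to compound 3 (within the scatter) in this assay and so provides the first reading at this position, which the earlier pair did not touch. Of the two steps read so far, only a 10-fold higher number from compound 1 to compound 2 (1.00 log units; beyond the scatter) on the carbonyl carbon lies beyond the scatter, so the sulfonyl side has not yet shown a change of that size. No measurement is available that would explain the result.

The names 2-chlorophenyl and 4-fluorophenyl differ in both the halogen and its number on the ring, and these two compounds do not separate those differences. On these data alone, it remains open how the series reads with an unsubstituted phenyl, a morpholine or a longer alkyl chain on the sulfonyl sulfur, and whether 4-fluorophenyl there would give the same reading with 2-methylphenyl on the carbonyl carbon.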